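Thiophen-2-yl to phenyl: notes on the series

The source may report more compounds than this note shows. Statements on the series, on what has been measured and on what is new or still open speak of the compounds shown alone.

Within the data shown here, in a functional assay on HL-60 cells (Homo sapiens) for cytotoxicity, read by CCK-8 assay, with a stated time of 24 h (a higher number here means a weaker inhibitor, a lower number a stronger inhibitor), compound 2 (`C=CC(=O)N1C(=O)CC(c2cccs2)Sc2ccccc21`) holds the highest of the two numbers so far (695000 nM), while compound 1 (`C=CC(=O)N1C(=O)CC(c2ccc(Br)cc2)Sc2ccccc21`) gives the lower one (126000 nM). Compound 3 (`C=CC(=O)N1C(=O)CC(c2ccccc2)Sc2ccccc21`) has phenyl in place of thiophen-2-yl on a saturated ring carbon. Among the measured compounds shown here, only one measured step bears on this change, and it is modest (a 5.5-fold higher number from compound 1 to compound 2 (0.74 log units; beyond the scatter)). Compound 3 resembles compound 1 in carrying a six-membered aromatic ring of carbon only, so a smaller step towards a lower number is expected in this assay. The estimated step is modest (a 2.3-fold lower number from compound 2 to compound 3 (0.36 log units; beyond the scatter)). Compound 3 is expected at 300000 nM (estimated range 120000 nM to 750000 nM).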

Compound 3, half-maximal inhibitory concentration: 97400 nM
Compound 3: middle estimate off by 3.1-fold (0.49 log units), on the high side, outside the stated range (below it).
By their numbers in this assay, from the lowest: compounds 3 and 1 (each within the scatter of the next); then compound 2.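

In this assay, phenyl in place of thiophen-2-yl on this saturated ring carbon gives a 7.1-fold lower number from compound 2 to compound 3 (0.85 log units; beyond the scatter), a larger step than the estimate allowed. The bromo group adds nothing that can be read here: hydrogen in place of bromo on the aromatic carbon gives a 1.3-fold lower number from compound 1 to compound 3 (0.11 log units; within the scatter), so compound 1 and compound 3 stand together. Among these three compounds, only the thiophen-2-yl of compound 2 stands apart from them.

From the compounds shown here alone, whether an amine, a methoxy group or a carboxylic acid on the phenyl ring would move the number remains open. No available evidence accounts for the step from thiophen-2-yl to phenyl.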